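The source may report more compounds than this note shows. Statements on the series, on what has been measured and on what is new or still open speak of the compounds shown alone.

Compounds measured in a functional assay on HCC827 cells (Homo sapiens) for antiproliferative activity, read by MTT assay, with a stated time of 72 h; on this read-out lower numbers stand for stronger inhibition and higher numbers for weaker inhibition:
- compound 1 `CN1CCN(c2ccc(Nc3ncc4nc([S+]([O-])c5ccccc5)n(C5CCOCC5)c4n3)cc2)CC1`: 411 nM
- compound 2 `CN1CCN(c2ccc(Nc3ncc4nc([S+]([O-])Cc5cccnc5)n(C5CCCC5)c4n3)cc2)CC1`: 2350 nM
- compound 3 `CN1CCN(c2ccc(Nc3ncc4nc(SCc5cccnc5)n(C5CCOCC5)c4n3)cc2)CC1`: 500 nM

Compound 3 stands second highest of the three numbers. Its nearest neighbour is compound 1, whose number in this assay is lower by a step within the scatter: a 1.2-fold higher number from compound 1 to compound 3 (0.09 log units; within the scatter). Compound 2 is furthest off, with a number well beyond the scatter above that of compound 3.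

Compound 4 `CN1CCN(c2ccc(Nc3ncc4nc(SCc5cccnc5)n(C5CCCC5)c4n3)cc2)CC1` is not yet measured. It differs from compound 3 in one place: cyclopentyl in place of oxan-4-yl on an aromatic nitrogen.

Among the compounds with values here, no measured step covers this change alone. Within the data shown here, the only step on record, from compound 1 to compound 3, concerns the group on the aromatic carbon, not the ring nitrogen, so it says nothing about this exchange. Among the measured compounds shown here, compound 2 carries a cyclopentyl but also differs from compound 3 at the sulfur, so its two values show only that the pair differs, not why. For the measured compounds named here, with no direct precedent, compound 4 is expected to land near compound 3, with an estimated step of a 1.8-fold higher number from compound 3 to compound 4 (0.26 log units; within the scatter) and wide uncertainty.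

Compound 4 is therefore expected to give about 900 nM in this assay, within a range from 350 nM to 2500 nM.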

Compound 4, half-maximal inhibitory concentration: 517 nM
The estimate for compound 4 lay 1.7-fold (0.24 log units) above the measured number; low and high end bracket the measured number.
By their numbers in this assay, from the lowest: compounds 1, 3 and 4 (each within the scatter of the next); then compound 2.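

In this assay the exchange at the aromatic nitrogen made no difference that could be told from scatter (a 1.0-fold higher number from compound 3 to compound 4 (0.01 log units; within the scatter)), so with the ((pyridin-3-yl)methyl)sulfanyl group in place, cyclopentyl and oxan-4-yl stand level. With cyclopentyl held on that nitrogen, the ((pyridin-3-yl)methyl)sulfanyl group in place of its sulfinyl counterpart gave a step beyond the scatter (a 4.5-fold lower number from compound 2 to compound 4 (0.66 log units; beyond the scatter)), so the change at the sulfur registers here while the change at the ring nitrogen does not. Nothing available explains either outcome.

As far as these compounds go, whether the two nitrogen groups would also stand level with the sulfinyl group in place remains open. So does the outcome for a piperidin-4-yl ring bearing a free amine, or for an open alkyl chain, on that nitrogen.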